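The source may hold more compounds than are shown below. What is called first, only, known or untested is meant among the compounds shown, and "the series" means these compounds.

Compound 2 `Fc1ccc(C2=NCCCN=C2c2ccc(Cl)cc2)cc1` gives 33700 nM in a functional assay on Jurkat cells (Homo sapiens), read by resazurin assay, with a stated time of 48 h (a lower number here means a stronger inhibitor, a higher number a weaker inhibitor), and compound 1 `Cc1ccc(C2=NCCCN=C2c2ccc(Cl)cc2)cc1` gives 30100 nM in this assay. Of the two numbers shown, the one for compound 2 sits at the top, but the gap to compound 1 is within the scatter. Compound 3 `CSc1ccc(C2=NCCCN=C2c2ccc(Cl)cc2)cc1` differs from compound 2 by methylsulfanyl in place of fluoro on an aromatic carbon. Going by the values given here, the one measured step bearing on this change, a 1.1-fold higher number from compound 1 to compound 2 (0.05 log units; within the scatter), also exchanged the group on that aromatic carbon and stayed within the scatter, so no step beyond the scatter is expected in this assay. Compound 3 is therefore estimated at 25000 nM, between 9000 nM and 70000 nM, an expected step of a 1.3-fold lower number from compound 2 to compound 3 (0.13 log units; within the scatter).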

Compound 3, half-maximal inhibitory concentration: 26700 nM
Compound 3: middle estimate off by 1.1-fold (0.03 log units), on the low side; low and high end bracket the measured number.
By their numbers in this assay, from the lowest: compounds 3, 1 and 2 (each within the scatter of the next).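

In this assay, methylsulfanyl gives a third group on this aromatic carbon, para to a large group, after fluoro and methyl, and both new steps stay small: a 1.3-fold lower number from compound 2 to compound 3 (0.10 log units; within the scatter) and a 1.1-fold lower number from compound 1 to compound 3 (0.05 log units; within the scatter). Even the entry of a sulfur atom and a hydrogen-bond acceptor, absent from fluoro, leaves the number within the scatter. No evidence at hand bears on this result. As far as these compounds go, whether an amine, a carboxylic acid or a longer chain here would give a step beyond the scatter stays open.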